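The source may report more compounds than this note shows. Statements on the series, on what has been measured and on what is new or still open speak of the compounds shown alone.

This study concerns three measured compounds and one not yet measured, all tested in an assay on isolated protein for inhibition of receptor-type tyrosine-protein phosphatase C (Homo sapiens), read by spectrophotometry; a lower number here means a stronger inhibitor, a higher number a weaker inhibitor. Compound 1 `Oc1cc(-c2ccccc2)ccc1C(O)(C(F)(F)F)C(F)(F)F` stands at a limit of the method: in this assay compound 1 gives > 500000 nM, which is a limit and not a number. Among the measured compounds shown here, compound 3 `Oc1c(-c2ccccc2)cccc1C(O)(C(F)(F)F)C(F)(F)F` is the only one with a plain number; in this assay compound 3 gives 157000 nM. Compound 2 `O=C(COc1ccc2cc(C(O)(C(F)(F)F)C(F)(F)F)c(O)cc2c1)Nc1ccccc1` also stands at a limit: in this assay compound 2 gives > 20000 nM, which is a limit and not a number. Compound 2 therefore stands at one of the two limits shown, and no step between measured compounds that differ in one place is available to lean on.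

Compound 4 `O=C(COc1ccc2cc(C(O)(C(F)(F)F)C(F)(F)F)c(O)cc2c1)Nc1cccc2ccccc12` differs from compound 2 in one place: naphthalen-1-yl in place of phenyl on an amide-type nitrogen. For the measured compounds named here, with no comparable step in hand, the expectation for this assay is a step of no size beyond the usual scatter, in either direction. Compound 4 is therefore expected to give about 30000 nM, with a range from 8000 nM to 150000 nM, and the method will quite possibly again report only a limit for it. This estimate means an expected step that the limit leaves unreadable from compound 2 to compound 4.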

Compound 4, half-maximal inhibitory concentration: 29100 nM
Compound 4: the middle estimate sits 1.0-fold (0.01 log units) above what was measured; the range from low to high includes it.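

Compound 2 gives > 20000 nM in this assay and that is a limit, not a number. Among the compounds shown here, compound 4 gives 29100 nM in the same test, so no step between compound 2 and compound 4 can be read. The compounds shown leave open whether naphthalen-1-yl in place of phenyl on the amide-type nitrogen changes inhibition at all, and in which direction.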